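Notes on the step to compound 3 in the series

The compounds below may be only part of what the source reports. "The series", "measured", "known", "first", "only" and "open" are said of these compounds alone.

Compound 2 `COc1cc(Cl)cc(-c2nn(-c3cccc(NC(=O)Nc4cccc(C(F)(F)F)c4)c3)cc2-c2ccncc2)c1` gives -25% in a functional assay on T47D cells (Homo sapiens) for inhibition, read by sulforhodamine B assay, with a stated time of 48 h, tested at 100 uM (on this read-out lower numbers stand for a stronger effect and higher numbers for a weaker effect at the one concentration tested), the lowest of the two numbers recorded so far; its nearest neighbour is compound 1 `COc1cc(Cl)cc(-c2nn(-c3cccc(NC(=O)Nc4ccc(Cl)c(C(F)(F)F)c4)c3)cc2-c2ccncc2)c1`, which gives -18%, and the step of a number 7 percentage points lower from compound 1 to compound 2 (within the scatter) is within the scatter. Compound 3 `COc1cc(Cl)cc(-c2nn(-c3cccc(NC(=O)c4cccc(C(F)(F)F)c4)c3)cc2-c2ccncc2)c1` differs from compound 2 by 3-(trifluoromethyl)phenyl in place of (3-(trifluoromethyl)phenyl)amino on a carbonyl carbon. Within the data shown here, no measured step touches this part of the molecule; the only step known concerns hydrogen in place of chloro on an aromatic carbon. The expected step is therefore a number 3 percentage points higher from compound 2 to compound 3 (within the scatter), nothing beyond the scatter. Compound 3 is estimated to give -22%, within -45% to 5%.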

Compound 3, a percentage reported as activity, at one concentration (the size of the read-out at that concentration, not a potency): 15%
Compound 3: middle estimate off by 37 percentage points, on the low side, outside the stated range (above it).
By their numbers in this assay, from the lowest: compounds 2 and 1 (each within the scatter of the next); then compound 3.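

The carbonyl carbon position responds where the chloro change did not: in this assay there is a number 40 percentage points higher from compound 2 to compound 3 (beyond the scatter) and a number 33 percentage points higher from compound 1 to compound 3 (beyond the scatter) when the amino link is lost and the aryl group sits directly on the carbonyl carbon. This change therefore weakens the effect at the one concentration tested. Nothing at hand explains the step.

Open, from the compounds shown here alone, is whether the amino nitrogen itself or only the length of the link matters; a methylene link or a methylamino link on the carbonyl carbon would separate the two. Also open, going by these compounds, is whether a chloro group on the 3-(trifluoromethyl)phenyl ring still changes little once the amino link is gone.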